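The source may hold more compounds than are shown below. What is called first, only, known or untested is meant among the compounds shown, and "the series" means these compounds.

In a functional assay on L6 cells (Rattus norvegicus) for inhibition (a lower number here means a stronger inhibitor, a higher number a weaker inhibitor), three compounds sharing one core have been measured. Compound 1 (`CC(C)c1c(C(=O)NCc2ccccc2)nn(-c2ccc(F)cc2)c1OC[C@@H](O)C[C@@H](O)CC(=O)O`) gives 880 nM, compound 2 (`CC(C)c1c(C(=O)NCc2cccc(F)c2F)nn(-c2ccc(F)cc2)c1OC[C@@H](O)C[C@@H](O)CC(=O)O`) gives 120 nM and compound 3 (`CC(C)c1c(C(=O)N2CCCC2c2ccccc2)nn(-c2ccc(F)cc2)c1OC[C@@H](O)C[C@@H](O)CC(=O)O`) gives 4340 nM, so compound 3 has the highest number and is the weakest inhibitor of the three. Compound 4 (`Cc1ccccc1CNC(=O)c1nn(-c2ccc(F)cc2)c(OC[C@@H](O)C[C@@H](O)CC(=O)O)c1C(C)C`) differs from compound 3 in one place: (2-methylbenzyl)amino in place of 2-phenylpyrrolidin-1-yl on a carbonyl carbon. In words, (2-methylbenzyl)amino stands in place of 2-phenylpyrrolidin-1-yl on a carbonyl carbon.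

The entering group resembles the benzylamino group of compound 1 and the (2,3-difluorobenzyl)amino group of compound 2. Two measured steps therefore bear on this change when read in reverse: the modest 4.9-fold higher number from compound 1 to compound 3 (0.69 log units; beyond the scatter) and the large 36-fold higher number from compound 2 to compound 3 (1.56 log units; beyond the scatter). Substitution on the phenyl ring also matters, as the modest 7.3-fold lower number from compound 1 to compound 2 (0.87 log units; beyond the scatter) shows, but no compound with a methyl group there has been measured. A modest to large drop in this assay is therefore expected. The estimated step is a 14-fold lower number from compound 3 to compound 4 (1.13 log units; beyond the scatter). For compound 4 the expected value is 320 nM, with an estimated range from 90 nM to 1100 nM.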

Compound 4, half-maximal inhibitory concentration: 2850 nM
The estimate for compound 4 lay 8.9-fold (0.95 log units) below the measured number; measured number outside the range, above it.
By their numbers in this assay, from the lowest: compound 2; then compound 1; then compounds 4 and 3 (each within the scatter of the next).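

In this assay, putting an open (2-methylbenzyl)amino group in place of the closed 2-phenylpyrrolidin-1-yl group gives no clear gain (a 1.5-fold lower number from compound 3 to compound 4 (0.18 log units; within the scatter)), so having a benzylamino-type amide with its amide hydrogen is not enough on its own for a stronger inhibitor. What is attached to the phenyl ring matters as much: methyl in place of hydrogen on an aromatic carbon weakens inhibition (a 3.2-fold higher number from compound 1 to compound 4 (0.51 log units; beyond the scatter)), and 2-methylphenyl in place of 2,3-difluorophenyl costs far more (a 24-fold higher number from compound 2 to compound 4 (1.38 log units; beyond the scatter)). Substituents on this ring can therefore move the number in either direction, since the two fluorines of compound 2 lower it and the methyl of compound 4 raises it, and nothing available explains that contrast. Going by these compounds, it remains open whether a single fluorine would be enough for the lower number. A chlorine or a methoxy group on this ring could behave like either fluorine or methyl.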